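Removing the para methoxy from compound 2

A few compounds are considered here, and "the series" means these few. Any claim that something is new, unique, unknown or untested is made for them only; others in the source may bear on it.

Compound 1 `COc1cc(-c2ncnn2-c2cccc(N)c2)cc(OC)c1OC`: > 10000 nM, a limit
Compound 2 `COc1ccc(-c2ncnn2-c2cc(OC)c(OC)c(OC)c2)cc1`: 950 nM
Compound 3 `COc1cc(-c2ncnn2-c2ccc(N)cc2)cc(OC)c1OC`: > 10000 nM, a limit

Going by the values given here, in a functional assay on K562 cells (Homo sapiens) for antiproliferative activity, read by MTT assay, with a stated time of 72 h (on this read-out lower numbers stand for stronger inhibition and higher numbers for weaker inhibition), compound 2 is the only compound with a number, at 950 nM. Compound 1 and compound 3 give only (the limit of > 10000 nM in this assay, at which 2 of the 3 values shown sit). Compound 4 `COc1cc(-n2ncnc2-c2ccccc2)cc(OC)c1OC` differs from compound 2 by hydrogen in place of methoxy on an aromatic carbon, para to a large group, so 4-methoxyphenyl becomes phenyl. Among the compounds with values here, the only measured step, a step that the two limits leave unreadable from compound 1 to compound 3, concerns an aminophenyl change and gives no size to carry over. Weaker inhibition is still expected, starting from compound 2 at 950 nM, the only measurable compound so far. The estimated change is a 4.2-fold higher number from compound 2 to compound 4 (0.62 log units; beyond the scatter). For compound 4 the estimate is 4000 nM, with an expected range of 1200 nM to 10000 nM.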

Compound 4, half-maximal inhibitory concentration: > 10000 nM
Compound 4: only a limit was reported (the forecaster's own chance of this, stated with the estimate: 35%); middle value at least 2.5-fold (0.39 log units) away from the limit.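

Methoxy on this aromatic carbon, para to a large group, matters in this assay: its replacement by hydrogen gives an at least 10-fold higher number from compound 2 to compound 4 (1.02 log units; beyond the scatter). Going by these compounds alone, this is the first step with a readable size, and it ties the number held by compound 2 to this one group. Compound 4 is reported only as a limit: the limit of > 10000 nM in this assay, at which 3 of the 4 values shown sit.

From the compounds shown here alone, how far the step runs past that limit stays open. So does whether a hydroxyl, an ethoxy or a fluorine atom at this position would keep the inhibition seen with methoxy.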